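Swapping the Pyridine Arm: Expected Effect on Solubility

This account rests on a few compounds, and the source may have more. Where it says the series, first, only, none or still open, it means among the compounds named here.

Of the compounds shown here, three have been measured in a physicochemical assay for solubility, read by HPLC, using the shake flask method, measured as kinetic solubility, with a stated time of 2 h, at pH 7.4; a lower number here means a less soluble compound, a higher number a more soluble compound. Compound 2 `Cc1cc(NCc2ccncc2)n2nc(C)c(-c3ccccc3)c2n1` gives 134000 nM, the highest of the three numbers. Compound 1 `Cc1cc(NCc2ccccn2)n2ncc(Br)c2n1` gives 89300 nM, which lies within the scatter of compound 2, so the two cannot be told apart. Compound 3 `Cc1cc(N(C)Cc2ccccn2)n2nc(C)c(-c3ccccc3)c2n1` gives 17500 nM, a step down from compound 2 that lies beyond the scatter. Compound 4 `Cc1cc(NCc2ccc(F)cn2)n2nc(C)c(-c3ccccc3)c2n1` has not been measured. Its difference from compound 2 is 5-fluoropyridin-2-yl in place of pyridin-4-yl on a saturated chain carbon bound to a nitrogen on an aromatic ring. Among the compounds with values here, no measured pair shows this exact change, so the direction rests on judgement alone. The expected step is a 1.9-fold lower number from compound 2 to compound 4 (0.28 log units; within the scatter), a small drop that may well lie within the scatter. Compound 4 is expected to give about 70000 nM in this assay, with a range from 25000 nM to 200000 nM.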

Compound 4, solubility: < 5000 nM
Compound 4 gave a limit, no number (the forecaster's own chance of this, stated with the estimate: 5%); middle value at least 14-fold (1.14 log units) from the limit.
By their numbers in this assay, from the lowest: compound 3; then compounds 1 and 2 (each within the scatter of the next). At a limit, below all of these: compound 4.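

In this assay, the group on the saturated chain carbon bound to a nitrogen on an aromatic ring proves far from a neutral swap: 5-fluoropyridin-2-yl in place of pyridin-4-yl gives an at least 26-fold lower number from compound 2 to compound 4 (1.42 log units; beyond the scatter). Within the data shown here, no earlier pair of compounds differed at this place alone. The lower end of this step is a limit of the assay, not a number: the limit of < 5000 nM in this assay, at which 1 of the 4 values shown sits.

This change alters the ring's point of attachment and adds fluorine at once, and the compounds shown do not separate the two. They also leave open how an amine or a carboxylic acid in place of the fluorine would read.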